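The source may report more compounds than this note shows. Statements on the series, on what has been measured and on what is new or still open speak of the compounds shown alone.

Three compounds built on one shared core have been taken into an ADME assay on the whole organism for pharmacokinetics, with Mus musculus as the target, at a dose of 10 mg/kg by the oral route; on this read-out lower numbers stand for lower exposure and higher numbers for higher exposure at the dose given. Compound 1 `CC1=C(c2cccc(O)c2)C(c2ccc(OC[C@@H](C)N3CCCC3)cc2)Oc2ccc(O)cc21` offers no figure to work with, being recorded as "not determined" (no result reported). Compound 2 `CC1=C(c2cccc(O)c2)C(c2ccc(OC[C@H](C)N3CC[C@@H](C)C3)cc2)Oc2ccc(O)cc21` gives 590 ng.h/mL, the lower of the two actual numbers, and compound 3 `CC1=C(c2ccc(F)cc2)C(c2ccc(OC[C@H](C)N3CC[C@@H](C)C3)cc2)Oc2ccc(O)cc21` gives 2000 ng.h/mL. Compound 4 `CC1=C(c2ccc(O)cc2)C(c2ccc(OC[C@H](C)N3CC[C@@H](C)C3)cc2)Oc2ccc(O)cc21` has yet to be measured.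

Compound 4 differs from compound 2 in a single group: 4-hydroxyphenyl in place of 3-hydroxyphenyl on a double-bonded ring carbon. The change is 4-hydroxyphenyl in place of 3-hydroxyphenyl on a double-bonded ring carbon, so the two compounds have the same atoms, joined differently.

Going by the values given here, only one measured step touches this group. It is a 3.4-fold higher number from compound 2 to compound 3 (0.53 log units; beyond the scatter), which exchanges 3-hydroxyphenyl for 4-fluorophenyl and lies beyond the scatter. That step is only a loose guide, since 4-fluorophenyl carries no hydroxy group while compound 4 keeps one. Among the compounds with values here, no measured pair shows what the exchange of 3-hydroxyphenyl for 4-hydroxyphenyl does on its own. A smaller move than that modest step therefore seems the reasonable expectation, with nothing beyond the scatter. The expected change is a 1.3-fold higher number from compound 2 to compound 4 (0.10 log units; within the scatter). For compound 4 the estimated value is 750 ng.h/mL, with an expected range of 250 ng.h/mL to 2200 ng.h/mL.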

Compound 4, area under the concentration-time curve: 460 ng.h/mL
Compound 4: the middle estimate sits 1.6-fold (0.21 log units) above what was measured, within the range that was stated.
By their numbers in this assay, from the lowest: compounds 4 and 2 (each within the scatter of the next); then compound 3.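

In this assay, 4-hydroxyphenyl in place of 3-hydroxyphenyl on the double-bonded ring carbon gives a 1.3-fold lower number from compound 2 to compound 4 (0.11 log units; within the scatter), so in this pair, where the hydroxy group sits on that phenyl ring makes no difference that can be told from the scatter. The exchange of hydroxy for fluoro on the same aromatic carbon gives a 4.3-fold lower number from compound 3 to compound 4 (0.64 log units; beyond the scatter), a step of similar size to a 3.4-fold higher number from compound 2 to compound 3 (0.53 log units; beyond the scatter), so among these three compounds, the clear gap in exposure lies between the two hydroxyphenyl compounds and the 4-fluorophenyl compound. No measurement is offered here that would explain this gap.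

From the compounds shown here alone, it remains open whether fluorine is as indifferent to its place as the hydroxy group seems to be, which a 3-fluorophenyl group would test against compound 3. Going by these compounds, it is also open whether a plain phenyl ring or a 4-methoxyphenyl group, neither of which carries a hydroxy group, would sit with compound 3 or with compound 2 and compound 4.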